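A few compounds are considered here, and "the series" means these few. Any claim that something is new, unique, unknown or untested is made for them only; others in the source may bear on it.

Of the compounds shown here, two built on one shared core have been measured in a functional assay on DU-145 cells (Homo sapiens) for antiproliferative activity, read by MTT assay, with a stated time of 24 h; on this read-out higher numbers stand for weaker inhibition and lower numbers for stronger inhibition. Compound 1 `COc1ccc(C(=O)/C=C/c2cc(-c3cc(OC)c(OC)c(OC)c3)n3nc(-c4ccccc4)cc3n2)cc1OC` gives 29900 nM. Among the measured compounds shown here, compound 2 `COc1ccc(C(=O)/C=C/c2cc(-c3ccc(OC)c(OC)c3)n3nc(-c4ccccc4)cc3n2)cc1` gives 14600 nM, the lower of the two numbers; compound 1, its only neighbour, stands at a higher number, and that gap lies beyond the usual scatter of the method.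

Compound 3 `COc1ccc(-c2cc(C(=O)/C=C/c3ccccc3)nc3cc(-c4ccccc4)nn23)cc1OC` has not yet been measured. It differs from compound 2 in a single place: (2-phenylethenyl)carbonyl in place of 2-((4-methoxyphenyl)carbonyl)ethenyl on an aromatic carbon The group that leaves is the longer of the two and carries a 4-methoxyphenyl ring; the group that enters is shorter and carries a plain phenyl ring.

For the measured compounds named here, no measured pair here follows a change of this kind, so the step of a 1.1-fold higher number from compound 2 to compound 3 (0.04 log units; within the scatter) is expected to be small, with no clear direction beyond the scatter. Compound 3 is therefore estimated at 16000 nM, within a range from 5000 nM to 50000 nM.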

Compound 3, half-maximal inhibitory concentration: 15600 nM
Compound 3: middle estimate off by 1.0-fold (0.01 log units), on the high side, and the stated range covers the measured number.
By their numbers in this assay, from the lowest: compounds 2, 3 and 1 (each within the scatter of the next, the first and the last beyond it).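

When (2-phenylethenyl)carbonyl takes the place of 2-((4-methoxyphenyl)carbonyl)ethenyl on this aromatic carbon, this assay shows a 1.1-fold higher number from compound 2 to compound 3 (0.03 log units; within the scatter) and the two compounds cannot be told apart. This position therefore accepts a shorter group, with the carbonyl and ethenyl parts in reversed order and a plain phenyl ring instead of a 4-methoxyphenyl ring, with no difference beyond the scatter. Nothing measured here explains why the two groups give such similar numbers.

The reversed order and the lost methoxy arrive together, so the share of each cannot be read, and they may either have little effect or cancel each other. On these data alone, it also remains open how this position would respond to a group of another kind, such as an amine or a carboxylic acid.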